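Swapping one aromatic group on a shared core

The source may hold more compounds than are shown below. What is called first, only, known or untested is meant among the compounds shown, and "the series" means these compounds.

Of the compounds shown here, three with the same core have been measured in a physicochemical assay for lipophilicity, using the shake flask method, in phosphate buffer, measured as octanol-water partition, with a stated time of 30 min, at pH 7.4; a lower number here means a more polar compound, a higher number a more lipophilic compound. Compound 1 `Cc1nc(CO)ccc1-c1cnc(NCc2c(F)ccc3c2CCO3)c2cn[nH]c(=O)c12` gives 2.4, compound 2 `Cc1ncc(-c2cnc(NCc3c(F)ccc4c3CCO4)c3cn[nH]c(=O)c23)n1C` gives 1.9, and compound 3 `Cc1nc(CN(C)C)ccc1-c1cnc(NCc2c(F)ccc3c2CCO3)c2cn[nH]c(=O)c12` gives 2. The data show a number 0.40 log units lower from compound 1 to compound 3 (beyond the scatter), and also a number 0.10 log units higher from compound 2 to compound 3 (within the scatter). Compound 3 therefore stands level with compound 2 and under compound 1.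

Compound 4 `CNC(=O)c1ncc(-c2cnc(NCc3c(F)ccc4c3CCO4)c3cn[nH]c(=O)c23)n1C` has not been measured. It carries 1-methyl-2-(methylcarbamoyl)-1H-imidazol-5-yl in place of the 6-((dimethylamino)methyl)-2-methylpyridin-3-yl of compound 3, on an aromatic carbon: 1-methyl-2-(methylcarbamoyl)-1H-imidazol-5-yl in place of 6-((dimethylamino)methyl)-2-methylpyridin-3-yl on an aromatic carbon.

Among the compounds with values here, the closest precedent is the exchange between this same pyridine group and 1,2-dimethyl-1H-imidazol-5-yl, where the data show a number 0.10 log units higher from compound 2 to compound 3 (within the scatter). Swapping these two groups alone therefore moved the number very little. The other steps are a caution, since changes at this site can matter: there is a number 0.50 log units lower from compound 1 to compound 2 (beyond the scatter). Within the data shown here, no measured step covers the methylcarbamoyl group that compound 4 has where compound 2 has a methyl, so the uncertainty is real and could run either way.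

The expected change is no change at the digits printed from compound 3 to compound 4 (within the scatter), which means no step beyond the scatter is anticipated in this assay. For compound 4 the estimated value is 2, within an expected range of 1.6 to 2.4.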

Compound 4, distribution coefficient: 2.5
The estimate for compound 4 lay 0.50 log units below the measured number, and the stated range ends below it.
By their numbers in this assay, from the lowest: compounds 2 and 3 (each within the scatter of the next); then compounds 1 and 4 (each within the scatter of the next).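

In this assay, methylcarbamoyl in place of methyl on the imidazole group gives a number 0.60 log units higher from compound 2 to compound 4 (beyond the scatter), so a change to that one substituent moves the number while the aromatic ring on the shared core stays the same. The earlier exchange of the 1,2-dimethyl-1H-imidazol-5-yl group for a pyridine group stayed within the scatter, but with 1-methyl-2-(methylcarbamoyl)-1H-imidazol-5-yl entering, replacing the dimethylamino pyridine group gives a number 0.50 log units higher from compound 3 to compound 4 (beyond the scatter) and replacing the hydroxymethyl pyridine group gives a number 0.10 log units higher from compound 1 to compound 4 (within the scatter) in the same assay, so the size of an exchange at this position depends on what both the leaving and the entering groups carry. Nothing available here gives a cause for these differences.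

The compounds shown leave open how a dimethylcarbamoyl group, a carboxylic acid or a longer chain such as ethylcarbamoyl would compare with methylcarbamoyl on the imidazole group, which would show whether the amide hydrogen or the size of the group goes with the number. They also leave open whether methylcarbamoyl on the 2-methylpyridin-3-yl group would match the hydroxymethyl or the dimethylamino compound.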